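This account rests on a few compounds, and the source may have more. Where it says the series, first, only, none or still open, it means among the compounds named here.

Measured compounds:
- compound 1, `O=C1C=C(Nc2ccc(I)cc2)C(=O)c2c1nc1n2[C@H]2OC[C@@H](O)[C@H]2OC1`: 4070 nM
- compound 2, `O=C1C(Nc2cccc(Cl)c2)=CC(=O)c2c1nc1n2[C@H]2OC[C@@H](O)[C@H]2OC1`: 7970 nM
- compound 3, `O=C1C(NC2CCCC2)=CC(=O)c2c1nc1n2[C@H]2OC[C@@H](O)[C@H]2OC1`: > 16000 nM

All three share one core and differ only in the group on the amine nitrogen. In a functional assay on HeLa cells (Homo sapiens) for inhibition, read by sulforhodamine B assay (a lower number here means a stronger inhibitor, a higher number a weaker inhibitor), compound 1 gives 4070 nM. Compound 2, with 3-chlorophenyl in that place, gives 7970 nM in this assay; the gap between compound 1 and compound 2 lies within the usual scatter, so the two cannot be ranked. Compound 3 carries cyclopentyl there, and its value in this assay is only a limit, (the limit of > 16000 nM in this assay, at which 1 of the 3 values shown sits), not a number.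

Compound 4, `O=C1C=C(NC2CCCC2)C(=O)c2c1nc1n2[C@H]2OC[C@@H](O)[C@H]2OC1`, is not yet measured. It relates to compound 1 as compound 3 relates to compound 2: cyclopentyl in place of 4-iodophenyl on an amine nitrogen.

Within the data shown here, only one measured step bears on this: an at least 2.0-fold higher number from compound 2 to compound 3 (0.30 log units; that floor lies within the scatter), where the same swap from an aromatic ring to cyclopentyl pushed the value to the limit. A weakening of at least that size is therefore expected for compound 4 in this assay, and the result may again be reported only as a limit. The expected step is a 4.9-fold higher number from compound 1 to compound 4 (0.69 log units; beyond the scatter), and compound 4 is estimated at 20000 nM, between 8000 nM and 50000 nM.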

Compound 4, half-maximal inhibitory concentration: > 16000 nM
Compound 4 gave a limit, no number; the forecaster's own chance of this, stated with the estimate: 60%; the middle value is on the limit's open side.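

The change from 4-iodophenyl to cyclopentyl in this assay gives an at least 3.9-fold higher number from compound 1 to compound 4 (0.59 log units; beyond the scatter), so this swap now has a measured effect that can be told apart from noise; the earlier step, an at least 2.0-fold higher number from compound 2 to compound 3 (0.30 log units; that floor lies within the scatter), could not show that on its own. As far as these compounds go, at this amine nitrogen, then, compound 1, with its aromatic ring, is a stronger inhibitor than compound 4, with its non-aromatic carbon ring, although the true size of the loss stays unknown and could be larger than this floor. Compound 3 and compound 4, the two cyclopentyl compounds, both stop at a limit rather than a number, so they cannot be ranked against each other: the limit of > 16000 nM in this assay, at which 2 of the 4 values shown sit.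

From the compounds shown here alone, it remains open whether the activity depends on the aromatic ring itself or on the iodine and chlorine it carries, a question that a plain phenyl ring on the same nitrogen would address. Going by these compounds, how a methoxy group on that ring, or an open carbon chain such as pentyl in place of the ring, would behave in this assay also remains open.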